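A few compounds are considered here, and "the series" means these few. Any claim that something is new, unique, unknown or untested is made for them only; others in the source may bear on it.

Compound 1 `CCOC(=O)c1cc(-c2cccc(OCc3cccc(C)c3)c2)on1` is examined in an ADME assay on Vero cells (Chlorocebus sabaeus) for cytotoxicity, with a stated time of 72 h; on this read-out lower numbers stand for stronger inhibition and higher numbers for weaker inhibition. Compound 1 gives only a limit there, > 128000 nM. Compound 2 `CCOC(=O)c1cc(-c2cccc(OCc3ccc(C(F)(F)F)cc3)c2)on1` likewise reaches only a limit in this assay, > 128000 nM. Both values therefore sit at the limit of > 128000 nM in this assay, at which 2 of the 2 values shown sit, so compound 1 stands at the same limit as the one other compound shown. Compound 3 `CCOC(=O)c1cc(-c2cccc(OCc3ccc(F)c(F)c3F)c2)on1` differs from compound 1 by 2,3,4-trifluorophenyl in place of 3-methylphenyl on a saturated chain carbon bound to an oxygen on an aromatic ring. With no measured step between compounds shown, compound 3 is expected to stay at the limit as well, the step that the limit leaves unreadable from compound 1 to compound 3 being no more than the usual scatter. Compound 3 is estimated at 160000 nM in this assay, within 64000 nM to 400000 nM.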

Compound 3, half-maximal inhibitory concentration: > 128000 nM
Compound 3: no number, only a limit (the forecaster's own chance of this, stated with the estimate: 85%); the middle value does not contradict the limit.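

Compound 3, like compound 1, gives only a limit, so no step between compound 1 and compound 3 can be read: the limit of > 128000 nM in this assay, at which 3 of the 3 values shown sit.

The compounds shown leave open where any true value lies in this assay, and whether 2,3,4-trifluorophenyl in place of 3-methylphenyl changes it at all.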